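Changing one ring on a shared core

The source may hold more compounds than are shown below. What is called first, only, known or untested is meant among the compounds shown, and "the series" means these compounds.

Measured in an ADME assay on MDCK cells (Canis lupus familiaris) for permeability, in the apical to basolateral direction (on this read-out higher numbers stand for higher permeability and lower numbers for lower permeability), so far:
Compound 1 `CC(C)C(CC1C(=O)NC(=O)N1C)c1ccc(-c2ccc3cccc(F)c3c2)[nH]c1=O` gives 17.6 10^-6 cm/s
Compound 2 `CC(C)C(c1ccc(-c2ccc3cccc(F)c3c2)[nH]c1=O)C1NC(=O)NC1=O` gives "not determined" (no result reported)
Compound 3 `CC(C)[C@H](C[C@H]1OC(=O)NC1=O)c1ccc(-c2ccc3cccc(F)c3c2)[nH]c1=O` gives 10.3 10^-6 cm/s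

Compound 2 has no number here, so it offers no starting value. Compound 1 and compound 3 lie within the usual scatter of each other. Compound 4 `CC(C)C(/C=C1\SC(=O)NC1=O)c1ccc(-c2ccc3cccc(F)c3c2)[nH]c1=O` carries, relative to compound 2, (a group of 8 heavy atoms (4 carbon, 1 nitrogen, 2 oxygen, 1 sulfur; one five-membered non-aromatic ring with 2 hetero atoms) in place of a group of 7 heavy atoms (3 carbon, 2 nitrogen, 2 oxygen; one five-membered non-aromatic ring with 2 hetero atoms), on a saturated chain carbon bound to an aromatic carbon and a saturated chain carbon). Within the data shown here, no measured step shows what such a swap does in this assay, so no step beyond the scatter is expected from the level of those two compounds, and no direction is favoured. For compound 4 the expected value is 12 10^-6 cm/s, with an estimated range of 5 10^-6 cm/s to 25 10^-6 cm/s.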

Compound 4, apparent permeability: 15.4 10^-6 cm/s
Compound 4: middle estimate off by 1.3-fold (0.11 log units), on the low side; the measured number falls inside the stated range.
By their numbers in this assay, from the lowest: compounds 3, 4 and 1 (each within the scatter of the next).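

Among these compounds, this is the first step that can be read at this position: in this assay, exchanging one five-membered ring for another that contains sulfur gives a 1.1-fold lower number from compound 1 to compound 4 (0.06 log units; within the scatter). So at this place on the chain, this swap moves the read-out no further than the scatter. Nothing measured here explains the result.

Still open, going by these compounds, is whether a group without such a ring, such as an amine or a carboxylic acid, would hold the number at this level. Whether a longer chain would do so is open too.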